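A few compounds are considered here, and "the series" means these few. Any claim that something is new, unique, unknown or untested is made for them only; others in the source may bear on it.

Measured so far:
compound 1, `CCOc1cc(=O)n(CCCO)c2c1CC(CC=C(C)C)C(C)(C)C2`: 16.6%
compound 2, `CC(C)=CCC1Cc2c(OCCCOc3ccc(Cl)cc3)cc(=O)n(CCCO)c2CC1(C)C`: 0%

In a functional assay on PANC-1 cells (Homo sapiens) for inhibition, read by MTT assay, with a stated time of 24 h, tested at 10 uM (a lower number here means less inhibition, a higher number more inhibition at the concentration tested (going by the name of the read-out)), compound 1 gives 16.6%, while compound 2 gives 0%. Compound 2 thus stands lowest of the two numbers, with compound 1 as its nearest neighbour. Going by the values given here, the one measured step, from compound 1 to compound 2, brought a number 16.6 percentage points lower from compound 1 to compound 2 (beyond the scatter), so lengthening the group on the aromatic-ring oxygen wiped out the inhibition seen for compound 1. Compound 3, `COc1cccc(NC(=O)Oc2cc(=O)n(CCCO)c3c2CC(CC=C(C)C)C(C)(C)C3)c1`, has not yet been tested in this assay. It differs from compound 2 at one place: (3-methoxyphenyl)carbamoyl in place of 3-(4-chlorophenoxy)propyl on an oxygen on an aromatic ring. The measured step bears on this only loosely, since the entering group is neither hydrogen nor the departing chain, and the direction cannot be read from a single step. The expectation for compound 3 is a partial return toward the level of compound 1, a step of a number 15 percentage points higher from compound 2 to compound 3 (beyond the scatter), giving an estimated 15% with a range from 0% to 40%.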

Compound 3, a percentage reported as inhibition, at one concentration (the size of the read-out at that concentration, not a potency): 0%
Compound 3: the middle estimate sits 15 percentage points above what was measured, within the range that was stated.
By their numbers in this assay, from the lowest: compounds 2 and 3 (each within the scatter of the next); then compound 1.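

In this assay, replacing 3-(4-chlorophenoxy)propyl with (3-methoxyphenyl)carbamoyl on the oxygen on the aromatic ring gives no change at the digits printed from compound 2 to compound 3 (within the scatter), so two groups with different linking atoms and different hydrogen-bond donor counts read alike at this position. Replacing the ethyl group with the carbamoyl group gives a number 16.6 percentage points lower from compound 1 to compound 3 (beyond the scatter), and this matches a number 16.6 percentage points lower from compound 1 to compound 2 (beyond the scatter), so among these three compounds the loss of inhibition is not tied to the chain of compound 2 alone. No measurement here explains why these two groups read alike.

From the compounds shown here alone, it remains open whether a propyl group or a 2-aminoethyl chain on this oxygen would keep, lose or raise the inhibition seen with ethyl. Going by these compounds, it is also open whether compound 2 and compound 3 would separate at another concentration.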